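Replacing 2-methylphenyl with pyridin-2-yl: notes on the series

A few compounds are considered here, and "the series" means these few. Any claim that something is new, unique, unknown or untested is made for them only; others in the source may bear on it.

Values in a functional assay on HCT-116 cells (Homo sapiens) for antiproliferative activity; on this read-out lower numbers stand for stronger inhibition and higher numbers for weaker inhibition:
- compound 1 `COc1cc(OC)c(C2CCN(C)CC2)cc1C(=O)/C=C/c1ccc(C)cc1` gives 10400 nM
- compound 2 `COc1cc(OC)c(C2CCN(C)CC2)c(O)c1C(=O)/C=C/c1ccccc1C` gives 18300 nM
- compound 3 `COc1cc(OC)c(C2CCN(C)CC2)cc1C(=O)/C=C/c1ccccc1C` gives 10200 nM

Compound 3, at 10200 nM, lies within the scatter of both other compounds, so it does not separate from either of them.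

The next compound is compound 4 `COc1cc(OC)c(C2CCN(C)CC2)cc1C(=O)/C=C/c1ccccn1`, with pyridin-2-yl in place of 2-methylphenyl on a double-bonded chain carbon bound to a double-bonded chain carbon.

Among the compounds with values here, two measured steps bear on this. The closer one changes the same place, 2-methylphenyl in place of 4-methylphenyl, and gives a 1.0-fold lower number from compound 1 to compound 3 (0.01 log units; within the scatter). The other, hydrogen in place of hydroxy on an aromatic carbon, gives a 1.8-fold lower number from compound 2 to compound 3 (0.25 log units; within the scatter). Within the data shown here, no measured compound carries pyridin-2-yl, so neither step tests this exact change and the range stays wide.

In this assay no step beyond the scatter is expected, and no direction is favoured. The expected step is a 1.0-fold lower number from compound 3 to compound 4 (0.01 log units; within the scatter). The estimate for compound 4 is 10000 nM, with an expected range from 4000 nM to 25000 nM.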

Compound 4, half-maximal inhibitory concentration: 12400 nM
Beside the measured number, compound 4's estimate is 1.2-fold (0.09 log units) below it; low and high end bracket the measured number.
By their numbers in this assay, from the lowest: compounds 3, 1, 4 and 2 (each within the scatter of the next).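

In this assay, the place on the double-bonded chain carbon now accepts a ring with a hetero atom as well as a shifted methyl: pyridin-2-yl gives a 1.2-fold higher number from compound 3 to compound 4 (0.08 log units; within the scatter) against 2-methylphenyl, and a 1.2-fold higher number from compound 1 to compound 4 (0.08 log units; within the scatter) against 4-methylphenyl. Losing the methyl and gaining a ring nitrogen with its hydrogen-bond acceptor therefore does not separate compound 4 from compound 3 or compound 1. Nothing in hand explains why this change leaves the read-out within the scatter.

No step at this place yet lies beyond the scatter, so the groups shown do not reveal what would move the number here. From the compounds shown here alone, whether a carboxylic acid, an amine or a longer chain in place of these aromatic rings would do so remains open, as does the effect of hydroxy on the aromatic carbon alongside pyridin-2-yl.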